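The source may hold more compounds than are shown below. What is called first, only, known or untested is meant among the compounds shown, and "the series" means these compounds.

The series shares a core in which an acylated sulfonamide links a bulky aryl group to a sulfonyl sulfur, tested in an assay on liver for inhibition of sterol O-acyltransferase 1 (Rattus norvegicus), using microsomes; on this read-out lower numbers stand for stronger inhibition and higher numbers for weaker inhibition. Compound 1 `CC(C)c1cccc(C(C)C)c1NC(=O)NS(=O)(=O)N1CCCCC1`, a urea rather than a carbamate, gives 17000 nM. Compound 2 `CCCCN(CCCC)S(=O)(=O)NC(=O)Oc1c(C(C)(C)C)cc(C)cc1C(C)(C)C`, a carbamate carrying a dibutylamino group on the sulfonyl sulfur, gives 3200 nM, the lowest of the two plain numbers shown, with compound 1 sitting a good way higher, a gap beyond the scatter. Compound 3 `Cc1cccc(C)c1OS(=O)(=O)NC(=O)Oc1c(C(C)C)cccc1C(C)C`, which carries an aryloxy group on the sulfonyl sulfur, reaches only the limit of > 50000 nM, a limit of the assay rather than a number; that is the situation described by the limit of > 50000 nM in this assay, at which 1 of the 3 values shown sits.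

Compound 4 `Cc1cc(C(C)(C)C)c(OC(=O)NS(=O)(=O)Oc2ccccc2)c(C(C)(C)C)c1` has not yet been measured. It differs from compound 2 by one change, (phenoxy in place of dibutylamino on a sulfonyl sulfur), that is, phenoxy in place of dibutylamino on a sulfonyl sulfur. Among the compounds with values here, no measured pair isolates this change. Within the data shown here, the only measured compound bearing an aryloxy group on the sulfonyl sulfur, compound 3, sits at the limit, while compound 2 gives a number. Compound 4 is therefore expected to lose ground, a step of a 4.7-fold higher number from compound 2 to compound 4 (0.67 log units; beyond the scatter) in this assay. The estimate for compound 4 in this assay is 15000 nM, within a range from 4000 nM to 50000 nM, with a real chance that only a limit is reported.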

Compound 4, half-maximal inhibitory concentration: 90000 nM
For compound 4 the middle estimate is 6.0-fold (0.78 log units) below the measured one; measured number outside the range, above it.
By their numbers in this assay, from the lowest: compound 2; then compound 1; then compound 4.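

In this assay, within the data shown here, the exchange of dibutylamino for phenoxy on a sulfonyl sulfur gives the first comparison in which only one place differs, and it produces a 28-fold higher number from compound 2 to compound 4 (1.45 log units; beyond the scatter). The group on the sulfonyl sulfur therefore matters greatly for inhibition in this series: with the rest of compound 2 unchanged, replacing an open dibutylamino group with a six-membered aromatic ring joined through oxygen weakens inhibition by a large step. Compound 3, which also carries an aryloxy group on the sulfonyl sulfur but differs from compound 4 in other places as well, remains a limit of the assay rather than a number: the limit of > 50000 nM in this assay, at which 1 of the 4 values shown sits.

This single step cannot show whether the loss follows from the oxygen, the aromatic ring, or the removal of the two butyl chains, since all three change together. As far as these compounds go, a phenylamino, cyclohexyloxy or dipropylamino group on the sulfonyl sulfur would separate these parts, and whether the same step holds on the urea of compound 1 also remains open.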